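Swapping the aromatic group of compound 2

The source may report more compounds than this note shows. Statements on the series, on what has been measured and on what is new or still open speak of the compounds shown alone.

- compound 1 `CCC(C)=C1C(=O)N(c2ccc(Cl)cc2)N(c2ccc(Cl)cc2)C1=O` gives 49200 nM
- compound 2 `COc1cc(C=C2C(=O)N(c3ccc(Cl)cc3)N(c3ccc(Cl)cc3)C2=O)ccc1O` gives 64900 nM
- compound 3 `CC(=C1C(=O)N(c2ccc(Cl)cc2)N(c2ccc(Cl)cc2)C1=O)c1ccc(O)cc1` gives 57000 nM

In a functional assay on SMMC-7721 cells (Homo sapiens) for cytotoxicity, read by MTT assay, with a stated time of 72 h (on this read-out higher numbers stand for weaker inhibition and lower numbers for stronger inhibition), compound 2 stands at 64900 nM in the same range as the other two. All three values lie within the scatter of one another, so compound 2 cannot be separated from compound 1 or compound 3.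

The next structure is compound 4 `O=C1C(=Cc2ccc(Cl)cc2Cl)C(=O)N(c2ccc(Cl)cc2)N1c1ccc(Cl)cc1` and the change is 2,4-dichlorophenyl in place of 4-hydroxy-3-methoxyphenyl on a double-bonded chain carbon bound to a double-bonded ring carbon on a double-bonded chain carbon bound to a double-bonded ring carbon. Within the data shown here, no measured compound carries 2,4-dichlorophenyl there, so the evidence is indirect. Among the measured compounds shown here, the one measured step is a 1.2-fold higher number from compound 1 to compound 3 (0.06 log units; within the scatter) with 4-hydroxyphenyl in place of ethyl on that kind of carbon, and it stays within the scatter.

In this assay the expected change is a 1.3-fold lower number from compound 2 to compound 4 (0.11 log units; within the scatter) and no step beyond the scatter is expected in either direction. Compound 4 is estimated at 50000 nM with 18000 nM to 100000 nM as the expected range.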

Compound 4, half-maximal inhibitory concentration: > 128000 nM
Compound 4 ended at the assay's limit; the forecaster's own chance of this, stated with the estimate: 10%; middle value at least 2.5-fold (0.40 log units) from the limit.
By their numbers in this assay, from the lowest: compounds 1, 3 and 2 (each within the scatter of the next). At a limit, above all of these: compound 4.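

In this assay, compound 4 stands at a limit of the assay, not at a number: the limit of > 128000 nM in this assay, at which 1 of the 4 values shown sits. From the compounds shown here alone, putting 2,4-dichlorophenyl in place of 4-hydroxy-3-methoxyphenyl on a double-bonded chain carbon bound to a double-bonded ring carbon gives an at least 1.9-fold higher number from compound 2 to compound 4 (0.29 log units; that floor lies within the scatter), so only a floor is known for this step, and its true size stays unknown. Of the groups shown at this place, 2,4-dichlorophenyl is the only one that ends at the limit, while the other three compounds all give numbers within the scatter of one another.

This one swap removes the hydrogen-bond donor and acceptors of the leaving group and brings in two chlorine atoms, so the compounds shown cannot tell which part of the change counts. Also open, going by these compounds, is how a phenyl ring carrying a single chlorine, an amine or a carboxylic acid would behave at this place.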